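A few compounds are considered here, and "the series" means these few. Any claim that something is new, unique, unknown or untested is made for them only; others in the source may bear on it.

Measured so far:
compound 1 `COc1cccc(OC)c1C(=O)Nc1c[nH]nc1C(=O)NN1CCOCC1` — > 50000 nM
compound 2 `CO[C@H]1CC[C@H](NC(=O)c2n[nH]cc2NC(=O)c2ccc(N3CCCC3)cc2)CC1` — > 50000 nM

In an ADME assay on MRC5 cells (Homo sapiens) for inhibition, with a stated time of 72 h (a lower number here means that less compound is needed, a higher number that more compound is needed for the effect), compound 1 gives > 50000 nM, a limit rather than a number. Compound 2 likewise gives only a limit, > 50000 nM. Compound 1 therefore stands at the limit of > 50000 nM in this assay, at which 2 of the 2 values shown sit, without a measured number to place it. Going by the values given here, no step between measured compounds covers the change toward compound 3 `COc1cccc(OC)c1C(=O)Nc1c[nH]nc1C(=O)Nc1ccncc1`, in which (pyridin-4-yl in place of morpholin-4-yl on an amide-type nitrogen). For this change in this assay no shift beyond the scatter is expected; the expected step is a number no higher from compound 1 to compound 3 (the limit leaves the size open), most likely ending again at the limit. Compound 3 is accordingly estimated at 50000 nM, between 20000 nM and 50000 nM.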

Compound 3, half-maximal effective concentration: > 50000 nM
Compound 3 was reported as a limit; the forecaster's own chance of this, stated with the estimate: 80%; the middle value lies on the limit itself.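

Compound 1 and compound 3 both stand only as limits in this assay, so no step can be read between them. The compounds shown leave open whether pyridin-4-yl in place of morpholin-4-yl changes the read-out at all, with every value so far at one limit: the limit of > 50000 nM in this assay, at which 3 of the 3 values shown sit.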